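This account rests on a few compounds, and the source may have more. Where it says the series, first, only, none or still open, it means among the compounds named here.

Measured compounds:
compound 1 `CC[C@@H]1C(=O)N(C)c2cnc(-n3ccc4cc(F)ccc43)nc2N1C1CCCC1` gives 21200 nM
compound 2 `CCC1C(=O)N(C)c2cnc(-n3ccc4cc(C(N)=O)ccc43)nc2N1c1ccn(C)n1` gives 31300 nM
compound 3 `CC[C@@H]1C(=O)N(C)c2cnc(Nc3ccc(S(N)(=O)=O)cc3)nc2N1C1CCCC1` gives 470 nM

All three numbers come from a functional assay on K562 cells (Homo sapiens) for antiproliferative activity, read by CCK-8 assay, with a stated time of 72 h; a lower number here means a stronger inhibitor of growth, a higher number a weaker inhibitor of growth. Compound 1 stands second highest of the three; compound 2 lies within the scatter of it, so no order between those two is claimed, while compound 3 sits far lower, beyond the scatter. Compound 4 `CC[C@@H]1C(=O)N(C)c2cnc(-n3ccc4cc(C(=O)NC5CCCC5)ccc43)nc2N1C1CCCC1` differs from compound 1 in one place: cyclopentylcarbamoyl in place of fluoro on an aromatic carbon. Going by the values given here, no measured pair shows this change, so its size is unknown. Compound 2, which also bears a carbamoyl group, is weak in this assay, which argues against a large gain. A small step downward in this assay is expected, a 1.8-fold lower number from compound 1 to compound 4 (0.25 log units; within the scatter), roughly within the scatter. Compound 4 is thus estimated at 12000 nM, with a range of 3000 nM to 40000 nM.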

Compound 4, concentration for 50% growth inhibition: 414 nM
Beside the measured number, compound 4's estimate is 29-fold (1.46 log units) above it, outside the stated range (below it).
By their numbers in this assay, from the lowest: compounds 4 and 3 (each within the scatter of the next); then compounds 1 and 2 (each within the scatter of the next).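

This aromatic carbon, para to a fused ring, takes far more than a single fluoro: in this assay, cyclopentylcarbamoyl in place of fluoro gives a 51-fold lower number from compound 1 to compound 4 (1.71 log units; beyond the scatter). Going by these compounds alone, this is the first single-place step, and it is beyond the scatter, so this position strongly affects growth inhibition. Nothing here bears on the reason for the step.

On these data alone, how much of the step belongs to the cyclopentyl ring and how much to the amide remains open. A methyl amide, a cyclopentyl ether or a carboxylic acid at this carbon, on the core of compound 1, would separate those parts.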